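The source may hold more compounds than are shown below. What is called first, only, known or untested is meant among the compounds shown, and "the series" means these compounds.

Compound 1 `CC(=O)Nc1cnc2[nH]c(=O)n([C@H]3CC[C@@H](C(C)(C)C)CC3)c(=O)c2c1` and compound 2 `CC(=O)Nc1cnc2[nH]c(=O)n([C@H]3CC[C@@H](C(C)C)CC3)c(=O)c2c1` share one core, while compound 3 `CC(C)[C@H]1CC[C@H](n2c(=O)[nH]c3ncc(N)cc3c2=O)CC1` and the not yet measured compound 4 `CC[C@H]1CC[C@H](n2c(=O)[nH]c3ncc(N)cc3c2=O)CC1` share another; how the two cores differ is not broken down here. In a physicochemical assay for solubility, read by nephelometry, measured as kinetic solubility (a higher number here means a more soluble compound, a lower number a less soluble compound), compound 1 gives only a limit, < 28000 nM. In this assay compound 2 gives 15000 nM and compound 3 gives 25000 nM. Compound 2 arises from compound 1 through (hydrogen in place of methyl on a saturated chain carbon bound to two saturated chain carbons and a saturated ring carbon), and that step reads a step that the limit leaves unreadable from compound 1 to compound 2. Compound 4 arises from compound 3 through (hydrogen in place of methyl on a saturated chain carbon bound to a saturated chain carbon and a saturated ring carbon), the same kind of change but not the same, since the carbon that loses the methyl is bound to one saturated chain carbon rather than two. With the earlier step unreadable, the expectation for compound 4 rests on compound 3 at 25000 nM and is a step of a 1.3-fold higher number from compound 3 to compound 4 (0.11 log units; within the scatter). Compound 4 is therefore expected to give about 32000 nM in this assay, most likely between 13000 nM and 80000 nM.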

Compound 4, solubility: 55000 nM
Estimate against measurement, compound 4: 1.7-fold (0.24 log units) below; low and high end bracket the measured number.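

In this assay the change from isopropyl to ethyl gives a 2.2-fold higher number from compound 3 to compound 4 (0.34 log units; beyond the scatter). This shows what the change does on the core of compound 3, and only there. It does not show that the change carries from one core to another, because the related step on the other core, which also removes a methyl from a differently bound carbon, cannot be read: the limit of < 28000 nM in this assay, at which 1 of the 4 values shown sits.

The compounds shown leave open how compound 4 would compare in this assay if a carboxylic acid or a longer chain such as butyl replaced its ethyl. They also leave open how an ethyl group would read on the core of compound 1.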